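Working notes: from compound 3 to compound 4

This account rests on a few compounds, and the source may have more. Where it says the series, first, only, none or still open, it means among the compounds named here.

Values in a functional assay on MIA PaCa-2 cells (Homo sapiens) for antiproliferative activity, read by MTT assay, with a stated time of 72 h; a higher number here means a weaker inhibitor, a lower number a stronger inhibitor:
- compound 1 `O=C1O/C(=C\Cn2cnc3ccn(C/C=C4\OC(=O)C(OCc5ccccc5)=C4OCc4ccccc4)c3c2=O)C(OCc2ccccc2)=C1OCc1ccccc1`: 26200 nM
- compound 2 `O=C1NC(O)(CCn2cnc3cc[nH]c3c2=O)C(OCc2ccccc2)=C1OCc1ccccc1`: 36600 nM
- compound 3 `O=C1NC(O)(CCn2cnc3cncc(Br)c32)C(OCc2ccccc2)=C1OCc1ccccc1`: 48700 nM

Compound 3 stands with compound 1 and compound 2 in a single band, each within the scatter of it. The next structure is compound 4 `O=C1NC(O)(CCn2cnc3ccnc(Cl)c32)C(OCc2ccccc2)=C1OCc1ccccc1`, and the change is a group of 10 heavy atoms (6 carbon, 3 nitrogen, 1 chlorine; one five-membered aromatic ring with 2 hetero atoms, one six-membered aromatic ring with 1 hetero atom) in place of a group of 10 heavy atoms (6 carbon, 3 nitrogen, 1 bromine; one five-membered aromatic ring with 2 hetero atoms, one six-membered aromatic ring with 1 hetero atom), on a saturated chain carbon, two bonds along the chain from a saturated ring carbon. Among the measured compounds shown here, the one measured step at this place is a 1.3-fold higher number from compound 2 to compound 3 (0.12 log units; within the scatter). That step swapped a group of the same size and stayed within the scatter, so no step beyond the scatter is expected in this assay. The expected step is a 1.2-fold lower number from compound 3 to compound 4 (0.06 log units; within the scatter). For compound 4 the estimated value is 42000 nM, with an expected range of 25000 nM to 80000 nM.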

Compound 4, half-maximal inhibitory concentration: 60000 nM
Compound 4: middle estimate off by 1.4-fold (0.15 log units), on the low side; measured number inside the range.
By their numbers in this assay, from the lowest: compounds 1, 2, 3 and 4 (each within the scatter of the next, the first and the last beyond it).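

In this assay, the group with chlorine in place of the group with bromine, on the saturated chain carbon, gives a 1.2-fold higher number from compound 3 to compound 4 (0.09 log units; within the scatter), while the same group in place of the oxygen-bearing group gives a 1.6-fold higher number from compound 2 to compound 4 (0.21 log units; within the scatter). The groups of 10 heavy atoms in compound 2, compound 3 and compound 4 therefore show no step beyond the scatter at this place. No measurement shown bears on why this is so.

On these data alone, whether an amine or a carboxylic acid at this place, or a longer chain carrying these groups, would give a step beyond the scatter remains open.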